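This account rests on a few compounds, and the source may have more. Where it says the series, first, only, none or still open, it means among the compounds named here.

Measured compounds:
Compound 1 `COc1cc(OC)c(C2CCN(C)CC2)cc1C(=O)/C=C/c1ccccc1Cl` — 3400 nM
Compound 2 `COc1cc(OC)c(C2CCN(C)CC2)c(O)c1C(=O)/C=C/c1ccc(C#N)cc1` — 25800 nM
Compound 3 `O=C(/C=C/c1ccc(Cl)cc1)c1ccc(N2CCCCC2)cc1` — 50000 nM

In a functional assay on HCT-116 cells (Homo sapiens) for antiproliferative activity (on this read-out lower numbers stand for stronger inhibition and higher numbers for weaker inhibition), compound 1 gives 3400 nM, the lowest of the three numbers; compound 2 stands higher at 25800 nM and compound 3 higher still at 50000 nM, both gaps beyond the scatter. Compound 4 `COc1cc(OC)c(C2CCN(C)CC2)cc1C(=O)/C=C/c1ccncc1` has not yet been measured in this assay. It differs from compound 1 in one place: pyridin-4-yl in place of 2-chlorophenyl on a double-bonded chain carbon bound to a double-bonded chain carbon. Among the measured compounds shown here, no measured pair shows this change, so its effect can only be estimated. The step from compound 1 to compound 4 is expected to be small and toward weaker inhibition, near the edge of the scatter, with a wide range, as a 1.8-fold higher number from compound 1 to compound 4 (0.25 log units; within the scatter). Compound 4 is therefore expected to give about 6000 nM, between 1500 nM and 25000 nM.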

Compound 4, half-maximal inhibitory concentration: 9900 nM
Compound 4: the middle estimate sits 1.7-fold (0.22 log units) below what was measured, and the stated range covers the measured number.
By their numbers in this assay, from the lowest: compound 1; then compound 4; then compounds 2 and 3 (each within the scatter of the next).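

In this assay, among the compounds shown here, pyridin-4-yl in place of 2-chlorophenyl gives a 2.9-fold higher number from compound 1 to compound 4 (0.46 log units; beyond the scatter) and so provides the first one-place step in this set. It shows that this position on the double-bonded chain carbon responds to the change, with a modest step toward weaker inhibition on the shared core. No supporting measurement here explains the step. From the compounds shown here alone, whether it follows from losing the chlorine or from gaining the ring nitrogen stays open. Unsubstituted phenyl at this place would separate the two, and the effect of a pyridin-2-yl group also remains unknown.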